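The compounds below may be only part of what the source reports. "The series", "measured", "known", "first", "only" and "open" are said of these compounds alone.

In a functional assay on SW480 cells (Homo sapiens) for antiproliferative activity, read by MTT assay, with a stated time of 48 h (on this read-out lower numbers stand for stronger inhibition and higher numbers for weaker inhibition), so far:
- compound 1 `COC/C1=C/C[C@](C)(CCC=C(C)C)/C=C/[C@@H](OC(=O)C=C(C)C)[C@](C)(O)/C=C/C1=O` gives 3850 nM
- compound 2 `CC(C)=CCC[C@]1(C)/C=C/[C@@H](OC(=O)C=C(C)C)[C@](C)(O)/C=C/C(=O)/C(CN(C)C)=C\C1` gives 480 nM

Compound 2 holds the lower of these two numbers, which means the stronger inhibition. Compound 3 `CCN(CC)C/C1=C/C[C@](C)(CCC=C(C)C)/C=C/[C@@H](OC(=O)C=C(C)C)[C@](C)(O)/C=C/C1=O` differs from it in one place (diethylamino in place of dimethylamino on a saturated chain carbon bound to a double-bonded ring carbon), with diethylamino in place of dimethylamino on a saturated chain carbon bound to a double-bonded ring carbon. Going by the values given here, the one measured step at that place (an 8.0-fold lower number from compound 1 to compound 2 (0.90 log units; beyond the scatter)) was modest and put dimethylamino in place of methoxy. Among the compounds with values here, no measured pair compares two amino groups, so this single step is the only guide. In this assay a smaller step is expected here, perhaps slightly upward, with nothing beyond the scatter. The expected change is small (a 1.3-fold higher number from compound 2 to compound 3 (0.10 log units; within the scatter)). Compound 3 is therefore estimated at 600 nM (200 nM to 1800 nM).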

Compound 3, half-maximal inhibitory concentration: 270 nM
For compound 3 the middle estimate is 2.2-fold (0.35 log units) above the measured one; measured number inside the range.
By their numbers in this assay, from the lowest: compounds 3 and 2 (each within the scatter of the next); then compound 1.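

Diethylamino in place of dimethylamino on a saturated chain carbon bound to a double-bonded ring carbon gives a 1.8-fold lower number from compound 2 to compound 3 (0.25 log units; within the scatter) in this assay, so these two amino groups cannot be told apart here. Diethylamino in place of methoxy at the same place gives a 14-fold lower number from compound 1 to compound 3 (1.15 log units; beyond the scatter) and so repeats, with a second amino group, the clear separation from methoxy that had rested on dimethylamino alone. Among these three compounds, then, the numbers separate between methoxy and either amino group, not between the two amino groups.

From the compounds shown here alone, whether a ring amine such as piperidine or morpholine, a primary amine or a carboxylic acid at this place would follow compound 2 and compound 3 or compound 1 stays open. Nothing further is available here to explain these numbers.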